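A few compounds are considered here, and "the series" means these few. Any claim that something is new, unique, unknown or untested is made for them only; others in the source may bear on it.

Compound 1 `COc1cc2[nH]c(=O)c(=O)oc2cc1OC` was examined in a functional assay on the whole organism for inhibition, with Rattus norvegicus as the target, at a dose of 25 mg/kg (on this read-out higher numbers stand for more inhibition at the one dose given (going by the name of the read-out) and lower numbers for less inhibition), where compound 1 gives 45%. Among the three measured compounds this is the top number, but its nearest neighbour, compound 2 `COC(=O)c1cc(OC)c2oc(=O)c(=O)[nH]c2c1`, which in this assay gives 35%, lies within the usual scatter of it, so the two cannot be ranked. Compound 3 `COc1ccc2oc(=O)c(=O)[nH]c2c1`, which gives 21%, is further away, and the step of a number 24 percentage points lower from compound 1 to compound 3 (beyond the scatter) is beyond the scatter, with the change being hydrogen in place of methoxy on an aromatic carbon.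

Compound 4 `COc1ccc2[nH]c(=O)c(=O)oc2c1` has not yet been measured. It differs from compound 1 by hydrogen in place of methoxy on an aromatic carbon. This is the same kind of change as that from compound 1 to compound 3, only the other methoxy group of compound 1 is the one removed. Among the measured compounds shown here, only that one step bears on the question, and it was modest but beyond the scatter. A drop of similar size is therefore expected for compound 4, the estimated step being a number 20 percentage points lower from compound 1 to compound 4 (beyond the scatter). Compound 4 is thus estimated to give about 25% in this assay, with a likely range from 10% to 40%.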

Compound 4, a percentage reported as inhibition, in the whole organism at one dose (the size of the read-out at that dose, not a potency): 33%
For compound 4 the middle estimate is 8 percentage points below the measured one; measured number inside the range.
By their numbers in this assay, from the lowest: compound 3; then compounds 4, 2 and 1 (each within the scatter of the next, the first and the last beyond it).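

In this assay, replacing this methoxy group, which sits ortho to the other methoxy group, with hydrogen gives a number 12 percentage points lower from compound 1 to compound 4 (beyond the scatter), so this position matters too. Read with a number 24 percentage points lower from compound 1 to compound 3 (beyond the scatter), the same change lowers the number beyond the scatter at both places on the core of compound 1, while compound 4, which keeps one methoxy group, still gives 33%. Nothing available explains why the number falls when either methoxy group is lost.

The compounds shown leave open whether this position needs a methoxy group specifically, or whether a hydroxyl, a chlorine atom, an amine or a longer chain such as ethoxy would hold the number. They also leave open what happens on the core when neither methoxy group is present.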